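Swapping trifluoromethyl for trifluoromethoxy in compound 3

The source may hold more compounds than are shown below. What is called first, only, known or untested is meant among the compounds shown, and "the series" means these compounds.

Measured in a functional assay on VCaP cells (Homo sapiens) for antiproliferative activity, read by propidium iodide staining, with a stated time of 96 h; a lower number here means a stronger inhibitor, a higher number a weaker inhibitor:
compound 1 `CC(O)(COc1ccc(S(F)(F)(F)(F)F)cc1)C(=O)Nc1cc(C(F)(F)F)cc(C(F)(F)F)c1`: 2400 nM
compound 2 `CC(O)(CS(=O)(=O)c1ccc(F)cc1)C(=O)Nc1ccc(S(F)(F)(F)(F)F)cc1`: 34200 nM
compound 3 `CC(O)(CS(=O)(=O)c1ccccc1C(F)(F)F)C(=O)Nc1ccc(S(F)(F)(F)(F)F)cc1`: 23800 nM

In this assay, compound 3 gives 23800 nM. This lies within the scatter of compound 2, which gives 34200 nM. Together they occupy the high end of the numbers, since compound 1 gives a much lower 2400 nM.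

The next compound is compound 4 `CC(O)(CS(=O)(=O)c1ccccc1OC(F)(F)F)C(=O)Nc1ccc(S(F)(F)(F)(F)F)cc1`, in which trifluoromethoxy stands in place of trifluoromethyl on an aromatic carbon, ortho to a large group, turning 2-(trifluoromethyl)phenyl into 2-(trifluoromethoxy)phenyl: trifluoromethoxy in place of trifluoromethyl on an aromatic carbon. Within the data shown here, no measured step makes this exact exchange. The nearest evidence is a single step at the same sulfonyl substituent, 2-(trifluoromethyl)phenyl in place of 4-fluorophenyl, which gave a 1.4-fold lower number from compound 2 to compound 3 (0.16 log units; within the scatter). That one change left the number within the scatter, and it is slim support, but it gives no reason to expect a large move in this assay from the smaller exchange now at hand. No step beyond the scatter is expected, and no direction is favoured. The expected change is a 1.0-fold higher number from compound 3 to compound 4 (0.00 log units; within the scatter). For compound 4 the estimated value is 24000 nM, with an expected range of 12000 nM to 46000 nM.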

Compound 4, half-maximal inhibitory concentration: 19900 nM
Compound 4: middle estimate off by 1.2-fold (0.08 log units), on the high side; low and high end bracket the measured number.
By their numbers in this assay, from the lowest: compound 1; then compounds 4, 3 and 2 (each within the scatter of the next).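

In this assay, trifluoromethoxy in place of trifluoromethyl on an aromatic carbon, ortho to a large group, gives a 1.2-fold lower number from compound 3 to compound 4 (0.08 log units; within the scatter) and so cannot be told apart from repeat measurement; this position accepts the extra oxygen and the one hydrogen-bond acceptor that enters with it without a readable shift in the number. Measured against the 4-fluorophenyl group on the sulfonyl sulfur, 2-(trifluoromethoxy)phenyl gives a 1.7-fold lower number from compound 2 to compound 4 (0.24 log units; within the scatter), which extends the earlier finding for 2-(trifluoromethyl)phenyl: all three sulfonyl compounds now sit within the scatter of one another, and none of these three aryl groups separates from the others. No independent measurement accompanies these numbers that could account for this result.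

Compound 1, at 2400 nM, differs from the sulfonyl compounds in more than one place, so its distance from them cannot be assigned to any single change. The compounds shown also leave open whether a methoxy group, a nitrile or an amine on the same aromatic carbon would stay within the scatter, or would finally move the number in this series.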